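Adding a Methoxy Group: Expected Step in Cytotoxicity

A few compounds are considered here, and "the series" means these few. Any claim that something is new, unique, unknown or untested is made for them only; others in the source may bear on it.

Measured compounds:
Compound 1 `COc1ccc(-c2cc(/C=C/C(=O)c3ccc(N)cc3)[nH]n2)cc1`: 65% in a functional assay on U-251 cells (Homo sapiens) for cytotoxicity, read by sulforhodamine B assay, with a stated time of 48 h, tested at 1 uM; on this read-out lower numbers stand for a stronger effect and higher numbers for a weaker effect at the one concentration tested
Compound 2 `COc1ccc(C(=O)/C=C/c2cc(-c3cc(OC)c(OC)c(OC)c3)n[nH]2)cc1OC`: 65% in this assay
Compound 3 `COc1ccc(-c2cc(/C=C/C(=O)c3ccc(N)cc3)[nH]n2)cc1OC`: 88% in this assay

Compound 1 and compound 3 differ by methoxy in place of hydrogen on an aromatic carbon, and this change gives a number 23 percentage points higher from compound 1 to compound 3 (beyond the scatter). The difference between the cores of compound 1 and compound 2 is not broken down here; in this assay their values are level at the digits given, within the scatter. Compound 4 `COc1cc(C(=O)/C=C/c2cc(-c3cc(OC)c(OC)c(OC)c3)n[nH]2)cc(OC)c1OC` arises from compound 2 by methoxy in place of hydrogen on an aromatic carbon. The place is not identical, since in compound 2 the carbon is also meta to a methoxy group, so this is the same kind of change rather than the same change. Compound 4 is expected to show a number 17 percentage points higher from compound 2 to compound 4 (beyond the scatter), because compound 1 and compound 3 gave a number 23 percentage points higher from compound 1 to compound 3 (beyond the scatter). Compound 4 is therefore estimated at 82%, between 62% and 100%.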

Compound 4, a percentage reported as activity, at one concentration (the size of the read-out at that concentration, not a potency): 83%
The estimate for compound 4 lay 1 percentage points below the measured number; measured number inside the range.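

In this assay, methoxy in place of hydrogen on an aromatic carbon gives a number 18 percentage points higher from compound 2 to compound 4 (beyond the scatter), so the change carries from one core to the other with a step of similar size: the same change on two cores in this assay, a number 23 percentage points higher (beyond the scatter) from compound 1 to compound 3 and a number 18 percentage points higher (beyond the scatter) from compound 2 to compound 4, 5 percentage points apart, within the scatter of two such steps. On both cores, the added methoxy goes with a higher number, which stands for a weaker effect at the one concentration tested. Among the compounds shown here, this rests on only two pairs, with the methoxy in different surroundings, and it does not show the reason for the step or that it holds on any further core.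

The compounds shown leave open whether a hydroxy group or a fluorine atom in place of that hydrogen would move the number in the same direction. They also leave open how a second added methoxy group would act on the core of compound 1.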